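Methoxy on the pendant phenyl of a chalcone series

This account rests on a few compounds, and the source may have more. Where it says the series, first, only, none or still open, it means among the compounds named here.

Measured compounds:
compound 1 `COc1cc(/C=C/C(=O)c2cccc(-n3cc(-c4ccccc4)[nH]c3=O)c2)ccc1O` with 2290 nM
compound 2 `COc1cc(/C=C/C(=O)c2cccc(-n3cc(-c4ccccc4)[nH]c3=O)c2)cc(OC)c1OC` with 390 nM

In a functional assay on SW-620 cells (Homo sapiens) for inhibition (a higher number here means a weaker inhibitor of growth, a lower number a stronger inhibitor of growth), compound 2 has the lowest number of the two measured compounds, and its nearest neighbour, compound 1, shows a number that stands beyond the scatter above it. Among the measured compounds shown here, the two compounds share a core and differ only in the pattern of methoxy groups on the ring that carries the double bond; no computed step for that pair is given, so only the two values themselves are stated here.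

Compound 3 `COc1ccc(-c2cn(-c3cccc(C(=O)/C=C/c4cc(OC)c(OC)c(OC)c4)c3)c(=O)[nH]2)cc1` is not yet measured. Compared with compound 2, the difference is methoxy in place of hydrogen on an aromatic carbon. For the measured compounds named here, no measured pair shows this particular change, so the size and direction of its step in this assay are unknown. The expectation is a small step, if any, that stays within the usual scatter. Compound 3 is therefore expected to give about 400 nM, within a range from 130 nM to 1200 nM, which corresponds to an expected step of a 1.0-fold higher number from compound 2 to compound 3 (0.01 log units; within the scatter).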

Compound 3, concentration for 50% growth inhibition: 450 nM
Beside the measured number, compound 3's estimate is 1.1-fold (0.05 log units) below it, within the range that was stated.
By their numbers in this assay, from the lowest: compounds 2 and 3 (each within the scatter of the next); then compound 1.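

In this assay, among the compounds shown here, replacing phenyl with 4-methoxyphenyl gives a 1.2-fold higher number from compound 2 to compound 3 (0.06 log units; within the scatter), so a methoxy group para to a large group is accommodated with no step that stands clear of the scatter. For the compounds shown here, compound 1 and compound 2 differ only on the ring that carries the double bond, whereas this pair gives the first reading for a change on the other phenyl ring, and it shows that added bulk of this kind at this position can be present while the number stays within the scatter. No supporting evidence accompanies this result, so the flat step remains an observation only.

Whether this position accepts other groups equally well remains open, as methoxy is the only replacement for hydrogen shown here, and an amine, a carboxylic acid or a longer alkoxy chain could give a different step. It is also open whether the same methoxy group would give a similar step with the methoxy pattern of compound 1 on the ring that carries the double bond, since the change is shown only with the pattern of compound 2.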